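From Benzyl to Phenyl on the Amide Nitrogen

The compounds below may be only part of what the source reports. "The series", "measured", "known", "first", "only" and "open" are said of these compounds alone.

In a functional assay on MDA-MB-435 cells (Homo sapiens) for cytotoxicity, read by MTT assay, with a stated time of 72 h (on this read-out higher numbers stand for weaker inhibition and lower numbers for stronger inhibition), compound 3 (`N[C@H]1CC[C@H](Nc2c(C(=O)NCc3ccccc3)nc(Br)c3cccnc23)CC1`) gives 7000 nM, and compound 1 (`COc1cccc(CNC(=O)c2nc(Br)c3cccnc3c2N[C@H]2CC[C@H](N)CC2)c1`) gives the same number, 7000 nM. Compound 2 (`N[C@H]1CC[C@H](Nc2c(C(=O)NCc3ccccn3)nc(Br)c3cccnc23)CC1`) gives 4000 nM, within the scatter of both. Compound 4 (`N[C@H]1CC[C@H](Nc2c(C(=O)Nc3ccccc3)nc(Br)c3cccnc23)CC1`) carries phenyl in place of benzyl on an amide-type nitrogen. Among the compounds with values here, no measured step makes this change. The nearest steps alter only the aromatic group on the chain carbon, no change at the digits printed from compound 1 to compound 3 (within the scatter) and a 1.8-fold higher number from compound 2 to compound 3 (0.24 log units; within the scatter), and so bear on it only indirectly. A step within the scatter in this assay is therefore expected, with no direction favoured, and the estimate is a 1.2-fold lower number from compound 3 to compound 4 (0.07 log units; within the scatter). For compound 4 the estimated value is 6000 nM, with an expected range from 2500 nM to 15000 nM.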

Compound 4, half-maximal inhibitory concentration: 1000 nM
Beside the measured number, compound 4's estimate is 6.0-fold (0.78 log units) above it, and the stated range ends above it.
By their numbers in this assay, from the lowest: compound 4; then compounds 2, 1 and 3 (each within the scatter of the next).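

Replacing benzyl with phenyl on the amide-type nitrogen gives a 7.0-fold lower number from compound 3 to compound 4 (0.85 log units; beyond the scatter) in this assay, whereas changing only the aromatic group on the chain carbon had stayed within the scatter. The other two benzyl-type amides point the same way, with a 4.0-fold lower number from compound 2 to compound 4 (0.60 log units; beyond the scatter) and a 7.0-fold lower number from compound 1 to compound 4 (0.85 log units; beyond the scatter), so among these compounds removing the chain carbon is the only change that moves the number beyond the scatter. No evidence given here accounts for this step.

From the compounds shown here alone, whether methoxy or a ring nitrogen on the anilino ring would alter the number remains open. So does the effect of a longer chain, such as 2-phenylethyl, on the amide-type nitrogen.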